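Moving one carbon along the chain: compound 2 to compound 3

A few compounds are considered here, and "the series" means these few. Any claim that something is new, unique, unknown or untested is made for them only; others in the source may bear on it.

Measured so far:
- compound 1, `CCN(C/C=C/C#CC(C)(C)C)Cc1cccc(OCCN(C)S(=O)(=O)c2cccnc2)c1`, gives 150 nM in a functional assay on HepG2 cells for inhibition of squalene monooxygenase (Homo sapiens); a higher number here means a weaker inhibitor, a lower number a stronger inhibitor
- compound 2, `CCN(C/C=C/C#CC(C)(C)C)Cc1cccc(OCCN(CC)S(=O)(=O)c2cccs2)c1`, gives 90 nM in this assay

For the measured compounds named here, compound 2 holds the lowest of the two numbers, but its only neighbour is compound 1, and the step of a 1.7-fold lower number from compound 1 to compound 2 (0.22 log units; within the scatter) lies within the scatter, so the two compounds cannot be ranked against each other on these data.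

Compound 3, `CCN(C/C=C/C#CC(C)(C)C)Cc1cccc(OCCCN(C)S(=O)(=O)c2cccs2)c1`, has not yet been measured. It differs from compound 2 by (methyl((thiophen-2-yl)sulfonyl)amino)methyl in place of ethyl((thiophen-2-yl)sulfonyl)amino on a saturated chain carbon, two bonds along the chain from an oxygen on an aromatic ring: the same atoms are present in both, joined differently, so that the chain carbon between the aromatic oxygen and the sulfonamide nitrogen is lengthened while the alkyl on that nitrogen is shortened.

Going by the values given here, no measured step addresses this rearrangement. Among the compounds with values here, the one step available, a 1.7-fold lower number from compound 1 to compound 2 (0.22 log units; within the scatter), changed the group on the sulfonamide nitrogen and the aromatic ring attached to the sulfonyl at once and stayed within the scatter. On that basis compound 3 is expected to show a step of a 1.2-fold higher number from compound 2 to compound 3 (0.09 log units; within the scatter), that is, no change beyond the scatter. The estimate for compound 3 in this assay is 110 nM, within a range from 40 nM to 300 nM.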

Compound 3, half-maximal inhibitory concentration: 6400 nM
Beside the measured number, compound 3's estimate is 58-fold (1.76 log units) below it, and the stated range ends below it.
By their numbers in this assay, from the lowest: compounds 2 and 1 (each within the scatter of the next); then compound 3.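

In this assay, this position proves sensitive to how the atoms are joined: on a saturated chain carbon, two bonds along the chain from an oxygen on an aromatic ring, (methyl((thiophen-2-yl)sulfonyl)amino)methyl in place of ethyl((thiophen-2-yl)sulfonyl)amino gives a 71-fold higher number from compound 2 to compound 3 (1.85 log units; beyond the scatter), even though the atoms and the counted features of the two groups are the same. The earlier pair gave no sign of this, as its groups differ in both the nitrogen alkyl and the sulfonyl-bound ring yet stay within the scatter of each other, whereas the step of a 43-fold higher number from compound 1 to compound 3 (1.63 log units; beyond the scatter) is also large and sets compound 3 clearly apart from both. Nothing available bears on the reason for this weakening.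

The compounds shown leave open which part of the rearrangement carries the step, the longer chain to the sulfonamide nitrogen or the methyl in place of ethyl on that nitrogen, as compound 3 changes both at once. They also leave open how the longer chain would fare with an ethyl on the sulfonamide nitrogen, or with a carboxamide in place of the sulfonamide.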